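The source may hold more compounds than are shown below. What is called first, only, known or untested is meant among the compounds shown, and "the series" means these compounds.

Measured compounds in an ADME assay on Huh7.5.1 cells (Homo sapiens) for cytotoxicity, read by ATP content, with a stated time of 48 h; on this read-out higher numbers stand for lower toxicity in this test and lower numbers for higher toxicity in this test:

Compound 1, `Cc1ccccc1-c1nc(CN2CCC(C(=O)NCCCN3CCC(C)(C)CC3)CC2)c(C)o1`, gives 10200 nM.
Compound 2, `Cc1ccccc1-c1nc(CN2CCC(C(=O)N3CCN(C4CCN(C)CC4)CC3)CC2)c(C)o1`, gives 19900 nM.
Compound 3, `Cc1oc(-c2c(Cl)cccc2C(F)(F)F)nc1CN1CCC(C(=O)NCCCN2C[C@H](C)C[C@H](C)C2)CC1`, gives 12000 nM.

Compound 3 sits close to the other two in this assay; its gap to compound 1 and its gap to compound 2 both lie within the usual scatter of repeated measurements, so the three numbers are not told apart by this test. Compound 4, `COc1ccc(-c2nc(CN3CCC(C(=O)NCCCN4C[C@H](C)C[C@H](C)C4)CC3)c(C)o2)cc1OC`, has not been measured. It differs from compound 3 in one place: 3,4-dimethoxyphenyl in place of 2-chloro-6-(trifluoromethyl)phenyl on an aromatic carbon. Nothing measured here shows how such a change moves the read-out, and the three known values all cluster together. The step of a 1.1-fold higher number from compound 3 to compound 4 (0.03 log units; within the scatter) is therefore expected to stay within the scatter, with no direction claimed. Compound 4 is estimated at 13000 nM, between 6000 nM and 30000 nM.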

Compound 4, half-maximal cytotoxic concentration: 57200 nM
Compound 4: middle estimate off by 4.4-fold (0.64 log units), on the low side; the whole stated range lies below it.
By their numbers in this assay, from the lowest: compounds 1, 3 and 2 (each within the scatter of the next); then compound 4.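

In this assay the group on this aromatic carbon can move the read-out beyond the scatter: 3,4-dimethoxyphenyl in place of 2-chloro-6-(trifluoromethyl)phenyl brings a 4.8-fold higher number from compound 3 to compound 4 (0.68 log units; beyond the scatter) and so lower toxicity in this test. The earlier compounds shown here, whose numbers could not be told apart, gave no sign of such a shift. Nothing measured here explains the step.

Still open, on these data alone, is whether the gain comes from adding the two methoxy groups or from losing the chloro and trifluoromethyl groups. A plain phenyl or a phenyl with a single methoxy group at this position would help separate the two.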